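The compounds below may be only part of what the source reports. "The series", "measured", "known", "first", "only" and "open" are said of these compounds alone.

Measured so far:
compound 1 `COc1cc(/C=C/C(=O)c2cccc(O)c2)ccc1O` — 62.6%
compound 2 `COc1ccc(/C=C/C(=O)c2ccc(OC)c(OC)c2)cc1` — 73.9%
compound 3 `COc1ccc(/C=C/C(=O)c2cccc(O)c2)cc1OC` — 63.9%

In an ADME assay on RAW264.7 cells (Mus musculus) for cytotoxicity, read by MTT assay, with a stated time of 24 h, tested at 10 ug/mL (on this read-out lower numbers stand for a stronger effect and higher numbers for a weaker effect at the one concentration tested), compound 1 gives 62.6%, compound 2 gives 73.9% and compound 3 gives 63.9%. Compound 2 has the highest of the three numbers, but its gap to compound 3 lies within the scatter, so no order between those two can be read; only its gap to compound 1 lies beyond the scatter. Compound 1 and compound 3 differ in one place: hydrogen in place of methyl on an oxygen on an aromatic ring. That change moved the read-out by a number 1.3 percentage points lower from compound 3 to compound 1 (within the scatter). The core of compound 2 and the core of compound 3 differ in more than one place, and that difference is not broken down here. Compound 4 `COc1ccc(/C=C/C(=O)c2ccc(O)c(OC)c2)cc1` has not yet been measured. It differs from compound 2 in one place: hydrogen in place of methyl on an oxygen on an aromatic ring. The surroundings of the place are the same in both pairs, so this is the same change made a second time. Because a number 1.3 percentage points lower from compound 3 to compound 1 (within the scatter) stayed within the scatter, the expected step is a number 2.9 percentage points lower from compound 2 to compound 4 (within the scatter). In this assay compound 4 is estimated at 71%, roughly between 60% and 82%.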

Compound 4, a percentage reported as activity, at one concentration (the size of the read-out at that concentration, not a potency): 62.3%
Compound 4: the middle estimate sits 8.7 percentage points above what was measured, within the range that was stated.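

In this assay, replacing methoxy with hydroxy on the core of compound 2 gives a number 11.6 percentage points lower from compound 2 to compound 4 (beyond the scatter), so on this core the change leaves a mark larger than the usual variation between repeats. Set beside the same change on the other core, the two steps cannot be told apart, even though only one of them stands clear of the scatter on its own: the same change on two cores in this assay, a number 1.3 percentage points lower (within the scatter) from compound 3 to compound 1 and a number 11.6 percentage points lower (beyond the scatter) from compound 2 to compound 4, 10.3 percentage points apart, within the scatter of two such steps. This fits a change that carries over from one core to the other, but two cores are a thin basis, and the data show neither that the step has one fixed size nor that the two cores respond differently.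

The compounds shown put only hydroxy in place of methoxy, so it stays open how an amine, a carboxylic acid or a longer chain such as ethoxy would read in that place. Each compound also has a reading at only one concentration, which leaves open how the effect would change at other concentrations.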